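From 2-chlorophenyl to 2-methoxyphenyl: one unmeasured step

The source may hold more compounds than are shown below. What is called first, only, known or untested is meant among the compounds shown, and "the series" means these compounds.

Compound 1 `CC1(C)[C@H]2CC[C@]1(C)N(Cc1cn(-c3ccccc3C#N)nn1)C(=O)C2`: 240 nM
Compound 2 `CC1(C)[C@H]2CC[C@]1(C)N(Cc1cn(-c3ccc(F)cc3)nn1)C(=O)C2`: 110 nM
Compound 3 `CC1(C)[C@H]2CC[C@]1(C)N(Cc1cn(-c3ccccc3Cl)nn1)C(=O)C2`: 270 nM

All three values come from a functional assay on PANC-1 cells (Homo sapiens) for inhibition, read by MTT assay, with a stated time of 24 h; a lower number here means a stronger inhibitor, a higher number a weaker inhibitor. Two measured steps place compound 3: a 1.1-fold higher number from compound 1 to compound 3 (0.05 log units; within the scatter), and a 2.5-fold higher number from compound 2 to compound 3 (0.39 log units; beyond the scatter). The first leaves it level with its cyano-bearing relative, while the second sets it apart from the 4-fluorophenyl compound.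

Compound 4 `COc1ccccc1-n1cc(CN2C(=O)C[C@@H]3CC[C@@]2(C)C3(C)C)nn1` departs from compound 3 at a single place: methoxy in place of chloro on an aromatic carbon. This is methoxy in place of chloro on an aromatic carbon, ortho to a large group.

The closest guide is the exchange of groups at this same place, a 1.1-fold higher number from compound 1 to compound 3 (0.05 log units; within the scatter). The other two steps, a 2.2-fold lower number from compound 1 to compound 2 (0.34 log units; beyond the scatter) and a 2.5-fold higher number from compound 2 to compound 3 (0.39 log units; beyond the scatter), were modest, but both involve the 4-fluorophenyl group and say less about this exchange. For the measured compounds named here, no methoxy compound has been measured, so the guide is thin, and no shift beyond the scatter is expected in this assay. The expected change is a 1.1-fold lower number from compound 3 to compound 4 (0.03 log units; within the scatter). For compound 4 the estimated value is 250 nM, with an expected range of 120 nM to 500 nM.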

Compound 4, half-maximal inhibitory concentration: 120 nM
For compound 4 the middle estimate is 2.1-fold (0.32 log units) above the measured one; the measured number falls inside the stated range.
By their numbers in this assay, from the lowest: compounds 2, 4, 1 and 3 (each within the scatter of the next, the first and the last beyond it).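

In this assay, the place ortho to a large group now proves sensitive to what it carries: methoxy for chloro gives a 2.3-fold lower number from compound 3 to compound 4 (0.35 log units; beyond the scatter) and so moves the number beyond the scatter, which the earlier chloro for cyano exchange did not do. Methoxy for cyano at the same place gives a 2.0-fold lower number from compound 1 to compound 4 (0.30 log units; within the scatter) and 2-methoxyphenyl for 4-fluorophenyl gives a 1.1-fold higher number from compound 2 to compound 4 (0.04 log units; within the scatter) and so compound 4 stands level with both of these compounds, showing that a group at this place need not separate a compound from the 4-fluorophenyl one. Nothing available explains why methoxy and chloro differ here.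

Going by these compounds, whether ethoxy, a longer chain, or an amine at this place would stay level with compound 4 remains open. Three groups at one place are too few to tie the numbers to any single feature.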